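A few compounds are considered here, and "the series" means these few. Any claim that something is new, unique, unknown or untested is made for them only; others in the source may bear on it.

In a functional assay on HOS-TE85 cells (Homo sapiens) for inhibition, read by CCK-8 assay, with a stated time of 72 h (a higher number here means a weaker inhibitor, a lower number a stronger inhibitor), compound 1 `COc1ccc(F)cc1N1C(=O)CSC1c1cccc(C(=O)NCCCCn2cccn2)c1` gives 97.3 nM and compound 2 `Cc1ccnc(N2C(=O)CSC2c2cccc(C(=O)NCCCCn3cccn3)c2)c1` gives 19.6 nM, the lower of the two numbers and so the stronger inhibitor of this pair. Compound 3 `O=C(NCCCCn1cccn1)c1cccc(C2SCC(=O)N2c2cc(F)ccn2)c1` differs from compound 2 in one place: fluoro in place of methyl on an aromatic carbon. In words, this is fluoro in place of methyl on an aromatic carbon, which turns 4-methylpyridin-2-yl into 4-fluoropyridin-2-yl. Going by the values given here, only one measured step bears on this, and only indirectly: a 5.0-fold lower number from compound 1 to compound 2 (0.70 log units; beyond the scatter), with 4-methylpyridin-2-yl in place of 5-fluoro-2-methoxyphenyl. Among the compounds with values here, that step exchanged a whole group, whereas this change swaps a single heavy atom, and no measured pair tests fluoro against methyl. A step of a 1.3-fold higher number from compound 2 to compound 3 (0.12 log units; within the scatter) is therefore expected, with no change beyond the scatter. For compound 3 the estimated value in this assay is 26 nM, with an expected range from 9 nM to 75 nM.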

Compound 3, half-maximal inhibitory concentration: 33.2 nM
Compound 3: the middle estimate sits 1.3-fold (0.11 log units) below what was measured, and the stated range covers the measured number.
By their numbers in this assay, from the lowest: compounds 2 and 3 (each within the scatter of the next); then compound 1.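

At the ring position opposite the nitrogen, fluoro can replace methyl without a change that stands out from the scatter: in this assay the swap gives a 1.7-fold higher number from compound 2 to compound 3 (0.23 log units; within the scatter). The advantage over the 5-fluoro-2-methoxyphenyl group is also not tied to the methyl, since 4-fluoropyridin-2-yl gives a 2.9-fold lower number from compound 1 to compound 3 (0.47 log units; beyond the scatter), a step beyond the scatter. No measurement available here explains why methyl and fluoro read alike at this position.

The compounds shown leave open how a larger or different group at this position, such as an amine, a methoxy group or a nitrile, would read. They also do not show whether a pyridin-2-yl ring with only hydrogen there would stay at the level of compound 2 and compound 3.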